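The source may report more compounds than this note shows. Statements on the series, on what has been measured and on what is new or still open speak of the compounds shown alone.

Measured compounds so far

- compound 1, `O=C(O)c1ccccc1SCc1cn(C/C=C/c2ccccc2)nn1`: in an ADME assay on Vero cells (Chlorocebus sabaeus) for cytotoxicity, read by MTT assay, with a stated time of 72 h (a higher number here means a weaker inhibitor, a lower number a stronger inhibitor), compound 1 stays at the limit > 200000 nM, which is a limit of the assay and not a number.
- compound 2, `CCCCCCCCCCCCCCCCn1cc(CSc2ccccc2C(=O)O)nn1`: in this assay compound 2 gives 27000 nM.

Among the compounds with values here, compound 2 carries the only numerical value; the other entry, for compound 1, is a limit, as noted in the limit of > 200000 nM in this assay, at which 1 of the 2 values shown sits. Within the data shown here, no step between two measured compounds is available, so no measured step size can be quoted.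

Compound 3, `CCCCCCCCCCCCCn1cc(CSc2ccccc2C(=O)O)nn1`, is the next member awaiting measurement. Its difference from compound 2 is hydrogen in place of propyl on a saturated chain carbon, ten or more bonds along the chain from an aromatic nitrogen. Nothing measured in this series bears on a change of this kind.

For compound 3 a step within or only slightly beyond the scatter is expected in this assay, if anything toward a weaker inhibitor, so the expected step is a 1.5-fold higher number from compound 2 to compound 3 (0.17 log units; within the scatter). Compound 3 is therefore estimated at 40000 nM, with a plausible range from 15000 nM to 150000 nM.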

Compound 3, half-maximal inhibitory concentration: 59000 nM
Estimate against measurement, compound 3: 1.5-fold (0.17 log units) below; the measured number falls inside the stated range.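

In this assay, the series now has its first readable step, a 2.2-fold higher number from compound 2 to compound 3 (0.34 log units; beyond the scatter), so a change on a saturated chain carbon is not silent, though the step is modest and lies only just beyond the scatter. The group that leaves is propyl and the group that enters is hydrogen, with no ring, no charge and no hydrogen-bond donor or acceptor in the change, so the alkyl chain alone is enough to move the number toward a weaker inhibitor in this pair. No measured property in the series bears on this step, and it stands as an observation without an explanation.

A single step does not show whether the number keeps rising as the chain gets shorter, levels off or reverses, and an octyl chain in place of the chain of compound 3 would test this. It also leaves open whether an amine on the same saturated chain carbon would behave as hydrogen does here.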